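From chloromethyl to trifluoromethyl on a carbonyl carbon

The source may report more compounds than this note shows. Statements on the series, on what has been measured and on what is new or still open speak of the compounds shown alone.

Values in a functional assay on MDA-MB-468 cells (Homo sapiens) for antiproliferative activity (a lower number here means a stronger inhibitor, a higher number a weaker inhibitor), each one a limit of the assay:
compound 1 `CC(=O)Nc1ccc(-c2nc3ccccc3s2)cc1C`: > 10000 nM
compound 2 `O=C(CCl)Nc1ccc(-c2nc3ccccc3s2)cc1`: > 100 nM
compound 3 `O=C(CCl)Nc1ccc(-c2nc3ccccc3s2)cc1I`: > 10 nM

Compound 2 is known only by its limit of > 100 nM, and no exact number stands beside it. Compound 4 `O=C(Nc1ccc(-c2nc3ccccc3s2)cc1)C(F)(F)F` departs from compound 2 by one change: trifluoromethyl in place of chloromethyl on a carbonyl carbon. Among the measured compounds shown here, the only measured step, a step that the two limits leave unreadable from compound 2 to compound 3, concerns another place and has no readable size, so it gives no measure for this change. The expectation leans instead on compound 1, whose limit is > 10000 nM. The expected step, a step that the limit leaves unreadable from compound 2 to compound 4, runs loosely toward weaker inhibition in this assay. Compound 4 is estimated at 1000 nM, with an expected range of 100 nM to 10000 nM.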

Compound 4, half-maximal inhibitory concentration: > 100 nM
Compound 4 gave a limit, no number; the forecaster's own chance of this, stated with the estimate: 55%; the middle value is on the limit's open side.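

Among the compounds shown here, compound 2 and compound 4 are each known only as a limit, so no step between them can be read. The compounds shown leave open what trifluoromethyl in place of chloromethyl on a carbonyl carbon does to inhibition.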